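Chloro to Methyl on the Shared Core: Compound 4

A few compounds are considered here, and "the series" means these few. Any claim that something is new, unique, unknown or untested is made for them only; others in the source may bear on it.

Three compounds have been measured in an assay on cell membranes for displacement of a labelled ligand from Adrenergic receptor alpha-1 (Rattus norvegicus); a higher number here means a weaker inhibitor, a lower number a stronger inhibitor:

Compound 1, `Cc1ccc2c(C3CCN(CCN4CCN(C(C)C)C4=O)CC3)cn(-c3ccccc3)c2c1`, gives 120 nM.
Compound 2, `CC(C)N1CCN(CCN2CCC(c3cn(-c4ccccc4)c4cc(Cl)ccc34)CC2)C1=O`, gives 39 nM.
Compound 3, `CN(C)C(=O)NCCN1CCC(c2cn(-c3ccc(F)cc3)c3cc(Cl)ccc23)CC1`, gives 29 nM.

Compounds 1 and 2 share a core and differ only by methyl in place of chloro on an aromatic carbon. That single change gives a 3.1-fold higher number from compound 2 to compound 1 (0.49 log units; beyond the scatter). Compound 3 carries a different side chain from compound 2; how the two cores differ is not broken down here, and the values of compound 3 and compound 2 lie within the scatter of each other, so no order between them is claimed. Compound 1 stands furthest from compound 3 in this assay.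

Compound 4, `Cc1ccc2c(C3CCN(CCNC(=O)N(C)C)CC3)cn(-c3ccc(F)cc3)c2c1`, is not yet measured. Among the measured compounds shown here, it differs from compound 3 by methyl in place of chloro on an aromatic carbon, the same change at the same place as the one seen between compound 2 and compound 1. The step from compound 3 to compound 4 is therefore expected to resemble that earlier step, a 3.1-fold higher number from compound 3 to compound 4 (0.49 log units; beyond the scatter), because of a 3.1-fold higher number from compound 2 to compound 1 (0.49 log units; beyond the scatter). Compound 4 is expected to give about 90 nM in this assay, with a likely range from 40 nM to 200 nM.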

Compound 4, half-maximal inhibitory concentration: 22 nM
Beside the measured number, compound 4's estimate is 4.1-fold (0.61 log units) above it; measured number below the stated range.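

In this assay, the exchange of chloro for methyl on an aromatic carbon did not carry over from one core to the other: the same change on two cores in this assay, a 3.1-fold higher number (0.49 log units; beyond the scatter) from compound 2 to compound 1 and a 1.3-fold lower number (0.12 log units; within the scatter) from compound 3 to compound 4, 4.1-fold (0.61 log units) apart, beyond the scatter of two such steps. The new step is a 1.3-fold lower number from compound 3 to compound 4 (0.12 log units; within the scatter), so on this core the change gives no order between the two compounds, whereas on the core of compound 2 it gave a clear step. Among the compounds shown here, this shows that the earlier step cannot simply be transferred, but it does not show which structural difference between the two pairs is responsible, as the pairs differ from each other in more than one place and only two such steps are available.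

The compounds shown leave open how other groups on the same aromatic carbon, such as bromo or methoxy, would behave on either core. They also leave open whether the exchange of chloro for methyl would follow either step on a core with a third side chain, such as one ending in a simple amide or a carboxylic acid.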